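Hydroxymethyl on the pendant phenyl of compound 2

The source may hold more compounds than are shown below. What is called first, only, known or untested is meant among the compounds shown, and "the series" means these compounds.

Two compounds of the series carry a number in an assay on CHO cells for displacement of a labelled ligand from adenosine receptor A1 (Homo sapiens), read by scintillation counting, with a stated time of 3 h; on this read-out higher numbers stand for weaker inhibition and lower numbers for stronger inhibition. Compound 1 `Cc1nc(N)c2nc(-c3ccccc3)sc2n1` gives 34 nM in this assay. Compound 2 `Nc1nc(-c2ccccc2)nc2sc(-c3ccccc3)nc12` gives 148 nM in this assay, the higher of the two numbers; the difference between them is a 4.4-fold higher number from compound 1 to compound 2 (0.64 log units; beyond the scatter), with phenyl in place of methyl on an aromatic carbon.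

Compound 3 `Nc1nc(-c2cccc(CO)c2)nc2sc(-c3ccccc3)nc12` is not yet measured. It differs from compound 2 by hydroxymethyl in place of hydrogen on an aromatic carbon; cut one bond further out, the change reads phenyl to 3-(hydroxymethyl)phenyl, on an aromatic carbon of a six-membered aromatic ring of carbon only, meta to a large group.

Among the compounds with values here, no measured step touches this position; the only step in hand concerns the exchange of methyl for phenyl on the core, not a substituent on that phenyl. The change therefore cannot be read from the series, and the expectation is a step of a 1.1-fold lower number from compound 2 to compound 3 (0.06 log units; within the scatter), which is within the scatter, with wide uncertainty in either direction. Compound 3 is estimated at 130 nM in this assay, expected to lie between 40 nM and 450 nM.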

Compound 3, inhibition constant: 32 nM
For compound 3 the middle estimate is 4.1-fold (0.61 log units) above the measured one; the whole stated range lies above it.
By their numbers in this assay, from the lowest: compounds 3 and 1 (each within the scatter of the next); then compound 2.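

The phenyl that replaced methyl on the core tolerates substitution at this place in this assay: hydroxymethyl in place of hydrogen gives a 4.6-fold lower number from compound 2 to compound 3 (0.67 log units; beyond the scatter), a change that runs opposite in direction to a 4.4-fold higher number from compound 1 to compound 2 (0.64 log units; beyond the scatter). The larger aryl group is therefore not in itself tied to the higher number, since the comparison with the methyl compound reads a 1.1-fold lower number from compound 1 to compound 3 (0.03 log units; within the scatter), leaving these two compounds unseparated. Nothing available gives a reason for the step at the pendant ring.

A single substituent at a single place cannot show whether the shift belongs to hydroxymethyl itself or would also come with a plain methyl, a methoxy, an aminomethyl or a carboxylic acid on the same aromatic carbon. Also open, as far as these compounds go, are a longer chain such as hydroxyethyl, hydroxymethyl elsewhere on this ring or on the other phenyl, and any reading of compound 3 beyond this single receptor.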